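Swapping the group on a sulfonamide nitrogen of compound 1

The source may report more compounds than this note shows. Statements on the series, on what has been measured and on what is new or still open speak of the compounds shown alone.

In a physicochemical assay for lipophilicity, at pH 7.4 (a higher number here means a more lipophilic compound, a lower number a more polar compound), compound 1 (`CC(C)CN(C1CCc2ccc(F)cc21)S(=O)(=O)c1ccc2c(c1)C(=O)CC(C1CCOCC1)O2`) gives 4.03. Among the compounds with values here, that is the higher of the two numbers measured so far, and the gap to compound 2 (`CCc1ccc(N(CC(C)C)S(=O)(=O)c2ccc3cc(OCC4CCOCC4)c(C(=O)O)cc3c2)cc1`), which gives 1.77, lies beyond the scatter.

The next compound to be measured is compound 3 (`CC(C)CN(c1cc2ccccc2s1)S(=O)(=O)c1ccc2c(c1)C(=O)CC(C1CCOCC1)O2`). It carries 1-benzothiophen-2-yl in place of 6-fluoro-2,3-dihydro-1H-inden-1-yl on a sulfonamide nitrogen, and the rest of compound 1 stays as it is: 1-benzothiophen-2-yl in place of 6-fluoro-2,3-dihydro-1H-inden-1-yl on a sulfonamide nitrogen. Neither group carries a net charge, and each holds one six-membered aromatic ring of carbon only.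

Within the data shown here, the two measured compounds differ in more than a single place, so no measured step guides this exchange. The expectation therefore starts from compound 1 at 4.03 and rests on the structural change alone. The estimated step in this assay, a number 0.17 log units higher from compound 1 to compound 3 (within the scatter), is expected to stay within the scatter, with a slight rise somewhat more likely than a fall. For compound 3 the expected value is 4.2, with an estimated range from 3.7 to 4.7.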

Compound 3, distribution coefficient: 4.01
Beside the measured number, compound 3's estimate is 0.19 log units above it, within the range that was stated.
By their numbers in this assay, from the lowest: compound 2; then compounds 3 and 1 (each within the scatter of the next).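

Within the data shown here, with this exchange on a sulfonamide nitrogen, this assay gives the first step that can be read at this position: a number 0.02 log units lower from compound 1 to compound 3 (within the scatter). The earlier compounds shown here, which differ in more than one place, could not show that 6-fluoro-2,3-dihydro-1H-inden-1-yl and 1-benzothiophen-2-yl, with their different five-membered rings and different hetero atoms, leave the number on the core of compound 1 within the scatter. Nothing measured here accounts for this result.

On these data alone, what an amine or a carboxylic acid in this place on the sulfonamide nitrogen would do to the number remains open. Both groups compared so far carry no net charge and each holds one six-membered aromatic ring of carbon only. As far as these compounds go, it also remains open whether the same exchange would give a step of similar size on the core of compound 2, and whether a group without any ring, such as a longer chain, would stay within the scatter of compound 1 as well.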